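Swapping Chloro for Fluoro on a Phenylpiperazine Amide

This account rests on a few compounds, and the source may have more. Where it says the series, first, only, none or still open, it means among the compounds named here.

Measured compounds:
- Compound 1 `COc1cccc(N2CCN(C(=O)c3oc(C(F)(F)F)nc3-c3cccc(F)c3)CC2)c1`: "not active" (no number reported)
- Compound 2 `Cc1nc(-c2ccccc2)c(C(=O)N2CCN(c3ccccc3Cl)CC2)o1`: 124 nM

In a functional assay on HL-60 cells (Homo sapiens) for inhibition, read by MTT assay, with a stated time of 72 h (on this read-out higher numbers stand for weaker inhibition and lower numbers for stronger inhibition), compound 1 is reported as "not active" (no number reported), with no number attached. Compound 2 gives 124 nM in this assay, and it holds the only number shown here; the further entry, compound 1, comes without a single value, so nothing can be said about how the two compare in size.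

Compound 3 `Cc1nc(-c2ccccc2)c(C(=O)N2CCN(c3ccccc3F)CC2)o1` is not yet measured. It differs from compound 2 in one place: fluoro in place of chloro on an aromatic carbon. Both groups are single heavy atoms that carry no donor, acceptor or charge, and the change sits ortho to a large group on the same six-membered ring of carbon only.

Among the compounds with values here, no step between measured compounds is available to guide the expectation, so only the small size of the change itself speaks. For compound 3 the expected result in this assay is 200 nM, within 70 nM to 600 nM. The expected step of a 1.6-fold higher number from compound 2 to compound 3 (0.21 log units; within the scatter) is small, leaning slightly toward weaker inhibition, and may not rise above the usual scatter.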

Compound 3, half-maximal inhibitory concentration: 147 nM
For compound 3 the middle estimate is 1.4-fold (0.13 log units) above the measured one, within the range that was stated.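

In this assay, within the data shown here, the first pair that can be read side by side gives a 1.2-fold higher number from compound 2 to compound 3 (0.07 log units; within the scatter), so compound 2 and compound 3 cannot be told apart on this read-out. On this aromatic carbon, ortho to a large group, the change from 2-chlorophenyl to 2-fluorophenyl therefore leaves the inhibition measured here unresolved from where it stood, something a single number could not show. Nothing measured here bears on the reason for this result.

From the compounds shown here alone, whether this carbon accepts more than a swap of one single heavy atom for another stays open, as an amine, a methoxy group or a carboxylic acid in the same place might give a very different reading. Also open, going by these compounds, is whether the same swap at another carbon of that ring would read the same way.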